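This account rests on a few compounds, and the source may have more. Where it says the series, first, only, none or still open, it means among the compounds named here.

In a functional assay on MT4 cells (Homo sapiens) for cytotoxicity (a lower number here means a stronger inhibitor, a higher number a weaker inhibitor), compound 1 `Cc1ccccc1Sc1cccc(N)c1C#N` reaches only the limit of the assay, > 40000 nM, a value that is a limit and not a number (the limit of > 40000 nM in this assay, at which 1 of the 3 values shown sits). Compound 2 `N#Cc1c(N)cccc1Sc1ccccc1Cl` gives 33000 nM in this assay. The two differ by chloro in place of methyl on an aromatic carbon, and the measured step is an at least 1.2-fold lower number from compound 1 to compound 2 (0.08 log units; that floor lies within the scatter). Compound 3 `Cc1cccc(S(=O)(=O)c2cccc(N)c2C#N)c1` gives 179000 nM in this assay, the higher of the two numbers, with compound 2 the nearest of the measured compounds. How the core of compound 3 differs from the core of compound 1 is not broken down here.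

Compound 4 `N#Cc1c(N)cccc1S(=O)(=O)c1cccc(Cl)c1` has not yet been measured. It differs from compound 3 by chloro in place of methyl on an aromatic carbon; this is the same kind of change as that from compound 1 to compound 2, though there the chloro sits ortho to a large group and here meta to a large group. Because the earlier step of an at least 1.2-fold lower number from compound 1 to compound 2 (0.08 log units; that floor lies within the scatter) lay within the scatter, only a small step of a 1.4-fold lower number from compound 3 to compound 4 (0.14 log units; within the scatter) is expected here. Compound 4 is therefore estimated to give 130000 nM in this assay, with a range from 55000 nM to 300000 nM.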

Compound 4, half-maximal inhibitory concentration: > 200000 nM
Compound 4 gave a limit, no number (the forecaster's own chance of this, stated with the estimate: 20%); middle value at least 1.5-fold (0.18 log units) from the limit.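

Compound 4 gives > 200000 nM in this assay, which is a limit of the assay and not a number. Chloro in place of methyl therefore gives only a floor for the step, an at least 1.1-fold higher number from compound 3 to compound 4 (0.04 log units; that floor lies within the scatter), so on this core the change can be read in one direction only and its true size remains unknown. The earlier step is also a floor, so the series does not show that the change carries over from one core to the other with the same size, nor that it behaves differently: the same change on two cores in this assay, an at least 1.2-fold lower number (0.08 log units; that floor lies within the scatter) from compound 1 to compound 2 and an at least 1.1-fold higher number (0.04 log units; that floor lies within the scatter) from compound 3 to compound 4; the limit leaves it open whether they differ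

The compounds shown leave open how the number in this assay would respond to other groups in place of methyl, such as fluoro, methoxy, a carboxylic acid or a longer chain. They also leave open how large either step is beyond its floor.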